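Amide heteroaryl swap on the phenylsulfonyl benzylamide series

This account rests on a few compounds, and the source may have more. Where it says the series, first, only, none or still open, it means among the compounds named here.

Three compounds in the series have numbers in an assay for inhibition of Nicotinamide phosphoribosyltransferase (Homo sapiens), read by mass spectrometry, with stated times of 15 min and 30 min; a higher number here means a weaker inhibitor, a lower number a stronger inhibitor. Compound 1 `O=C(NCc1ccc(S(=O)(=O)c2ccccc2)cc1)c1nc2ccncc2s1` gives 210 nM in this assay and stands second highest of the three. Compound 2 `O=C(NCc1ccc(S(=O)(=O)c2ccccc2)cc1)c1cc(-c2cccnc2)no1` gives 41 nM in this assay, a lower number than compound 1 and beyond the scatter. Compound 3 `O=C(NCc1ccc(S(=O)(=O)N2CCCCC2)cc1)c1ccn2ccnc2c1` gives 1800 nM in this assay, a higher number than compound 1 and also beyond the scatter. Among the measured compounds shown here, no pair of these differs in one place only, so no single change has a measured step attached to it.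

Compound 4 `O=C(NCc1ccc(S(=O)(=O)c2ccccc2)cc1)c1cnc2nccn2c1` is not yet measured. It differs from compound 1 by a group of 9 heavy atoms (6 carbon, 3 nitrogen; one five-membered aromatic ring with 2 hetero atoms, one six-membered aromatic ring with 2 hetero atoms) in place of a group of 9 heavy atoms (6 carbon, 2 nitrogen, 1 sulfur; one five-membered aromatic ring with 2 hetero atoms, one six-membered aromatic ring with 1 hetero atom), on a carbonyl carbon. Both groups are bicyclic aromatic systems of the same heavy-atom count on the carbonyl carbon, and the rest of the molecule is kept. For the measured compounds named here, with no measured step for this change, the expectation is a small step from compound 1 to compound 4 of a 1.5-fold higher number from compound 1 to compound 4 (0.18 log units; within the scatter), within or close to the scatter, leaning toward a higher number. Compound 4 is therefore estimated at 320 nM in this assay, with a range of 80 nM to 1300 nM.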

Compound 4, half-maximal inhibitory concentration: 2 nM
Compound 4: the middle estimate sits 160-fold (2.20 log units) above what was measured; measured number outside the range, below it.
By their numbers in this assay, from the lowest: compound 4; then compound 2; then compound 1; then compound 3.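

In this assay, the group on the carbonyl carbon proves to be a highly sensitive place in this series: the swap gives a 110-fold lower number from compound 1 to compound 4 (2.02 log units; beyond the scatter), although both groups have 9 heavy atoms, the same ring sizes and the same hydrogen-bond donor and acceptor counts. What differs in the counts is small: one sulfur leaves, one nitrogen enters, and the six-membered aromatic ring goes from 1 hetero atom to 2. Nothing available explains why this pair shows so large a step.

Going by these compounds, whether a methyl group or a chlorine on the entering group would keep a number as low as that of compound 4 remains open. Also open, on these data alone, is whether the entering group gives a similar step when paired with the sulfonyl substituent of compound 3.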